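The source may report more compounds than this note shows. Statements on the series, on what has been measured and on what is new or still open speak of the compounds shown alone.

Compound 1 `COc1ccc(C(=O)N/N=C/c2cc(C(C)(C)C)ccc2O)cc1` is the starting point. In a functional assay on MRC5 cells (Homo sapiens) for cytotoxicity, read by colorimetric assay and MTT assay (a lower number here means that less compound is tolerated, a higher number that more compound is tolerated), compound 1 gives > 100000 nM, which is a limit of the assay rather than a measured number. Compound 1 therefore stands at the limit of > 100000 nM in this assay, at which 1 of the 2 values shown sits. A second compound, compound 2 `CCN(CC)c1ccc(/C=N/NC(=O)c2ccc(C(C)(C)C)cc2)c(O)c1`, differs from compound 1 in more than one place; in this assay compound 2 gives 1100 nM, a measured number well inside the range the assay reports. The next compound to be tested is compound 3 `CC(C)(C)c1ccc(O)c(/C=N/NC(=O)c2cccs2)c1`. It differs from compound 1 in a single place: thiophen-2-yl in place of 4-methoxyphenyl on a carbonyl carbon. For the measured compounds named here, no step between two measured compounds covers this change, so its effect in this assay is open. Because compound 1 sits at the limit of > 100000 nM in this assay, at which 1 of the 2 values shown sits, only a move to a lower number could be seen as a value at all. The expectation is that compound 3 lands near 50000 nM, within a broad range from 10000 nM to 200000 nM. That estimate means an expected step of an at least 2.0-fold lower number from compound 1 to compound 3 (0.30 log units; that floor lies within the scatter), while another limit would not be surprising.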

Compound 3, half-maximal cytotoxic concentration: 12000 nM
Beside the measured number, compound 3's estimate is 4.2-fold (0.62 log units) above it; the measured number falls inside the stated range.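

In this assay, the group on the carbonyl carbon turns out to matter: thiophen-2-yl in place of 4-methoxyphenyl gives an at least 8.3-fold lower number from compound 1 to compound 3 (0.92 log units; beyond the scatter). With the rest of the molecule unchanged, this single swap is enough to turn a compound with no measured value into one with a measured cytotoxic concentration, something compound 2 could not show, as it differs from compound 1 in more than one place. The true size of the step remains unknown, and only its minimum can be stated, because compound 1 carries a limit of the assay rather than a measured number: the limit of > 100000 nM in this assay, at which 1 of the 3 values shown sits.

The compounds shown leave open which part of the swap goes with the lower number: the smaller ring, the sulfur atom or the loss of the methoxy group, and an unsubstituted phenyl, a furan-2-yl or a pyridine ring at the same place would help to tell these apart. On these data alone, it is also open whether the same swap would lower the number on the core of compound 2, and whether any other group on the carbonyl carbon, such as an amine-bearing ring, would go further or reverse the change.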